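The source may report more compounds than this note shows. Statements on the series, on what has been measured and on what is new or still open speak of the compounds shown alone.

Measured compounds:
compound 1, `O=C(CSc1nc(Nc2ccccc2)c2ccccc2n1)Nc1ccccc1F`, 12400 nM
compound 2, `C=CC(=O)Nc1cccc(NC(=O)CSc2nc(Nc3ccccc3Br)c3ccccc3n2)c1`, 17100 nM

Both were tested in a functional assay on PC-3 cells (Homo sapiens) for inhibition, read by MTT assay, with a stated time of 72 h; a lower number here means a stronger inhibitor, a higher number a weaker inhibitor. Compound 2 stands at the high end of the two numbers, yet its gap to compound 1 lies within the usual scatter, so the two cannot be told apart. Compound 3, `C=CC(=O)Nc1cccc(NC(=O)CSc2nc(Nc3ccc(C(F)(F)F)cc3)c3ccccc3n2)c1`, is not yet measured; it differs from compound 2 in one place: 4-(trifluoromethyl)phenyl in place of 2-bromophenyl on a nitrogen on an aromatic ring. Among the compounds with values here, no step between measured compounds is available to show how much such a change matters, so the expected step is a 1.2-fold lower number from compound 2 to compound 3 (0.09 log units; within the scatter), small and not clearly beyond the scatter. Compound 3 is therefore expected to give about 14000 nM, within a range of 5000 nM to 40000 nM.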

Compound 3, half-maximal inhibitory concentration: 12500 nM
Compound 3: the middle estimate sits 1.1-fold (0.05 log units) above what was measured; the range from low to high includes it.
By their numbers in this assay, from the lowest: compounds 1, 3 and 2 (each within the scatter of the next).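

In this assay the swap of 2-bromophenyl for 4-(trifluoromethyl)phenyl on the nitrogen gives a 1.4-fold lower number from compound 2 to compound 3 (0.14 log units; within the scatter) and leaves the two compounds impossible to tell apart. Within the data shown here, this is the first measured step at this position, and it shows that this exchange of one substituted phenyl for another has no readable effect here. Open, as far as these compounds go, is whether an amine or a carboxylic acid on this ring would separate from these values, and whether bromine and trifluoromethyl would match at the same ring position. Nothing measured here explains the result.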